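Ester chain length and cytotoxicity in HeLa cells

This account rests on a few compounds, and the source may have more. Where it says the series, first, only, none or still open, it means among the compounds named here.

Measured compounds:
Compound 1, `CCCCCC(=O)O[C@H]1[C@H](O)[C@H](n2ccc(N)nc2=O)O[C@@H]1CO`: 0.05 ug/mL
Compound 2, `CCCCCCCCCCCC(=O)O[C@H]1[C@H](O)[C@H](n2ccc(N)nc2=O)O[C@@H]1CO`: 0.08 ug/mL
Compound 3, `CCCCCCCC(=O)O[C@H]1[C@H](O)[C@H](n2ccc(N)nc2=O)O[C@@H]1CO`: 0.1 ug/mL

In a functional assay on HeLa cells (Homo sapiens) for cytotoxicity, read by cell counting, with a stated time of 48 h (a higher number here means that more compound is needed for the effect, a lower number that less compound is needed), compound 3 gives 0.1 ug/mL. Its number is separated from that of compound 2 by a 1.3-fold higher number from compound 2 to compound 3 (0.10 log units; within the scatter) and from that of compound 1 by a 2.0-fold higher number from compound 1 to compound 3 (0.30 log units; within the scatter); both gaps lie within the usual scatter, so the three compounds cannot be told apart on these numbers.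

Compound 4, `CCCCCCCCC(=O)O[C@H]1[C@H](O)[C@H](n2ccc(N)nc2=O)O[C@@H]1CO`, has not yet been measured. It differs from compound 3 by methyl in place of hydrogen on a saturated chain carbon, seven bonds along the chain from a carbonyl carbon. The steps already seen bear directly on this: lengthening the chain by a larger amount gave a 1.6-fold higher number from compound 1 to compound 2 (0.20 log units; within the scatter), by a smaller amount a 2.0-fold higher number from compound 1 to compound 3 (0.30 log units; within the scatter), and shortening it gave a 1.3-fold higher number from compound 2 to compound 3 (0.10 log units; within the scatter). None of these passed the scatter, so no step beyond the scatter is expected in this assay from adding one more chain carbon, in either direction.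

Compound 4 is therefore estimated at 0.09 ug/mL, with a range from 0.04 ug/mL to 0.2 ug/mL, which means an expected step of a 1.1-fold lower number from compound 3 to compound 4 (0.05 log units; within the scatter).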

Compound 4, concentration for half-maximal effect: 0.05 ug/mL
Compound 4: the middle estimate sits 1.8-fold (0.26 log units) above what was measured, and the stated range covers the measured number.
By their numbers in this assay, from the lowest: compounds 1, 4, 2 and 3 (each within the scatter of the next).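

In this assay, methyl in place of hydrogen at this place, seven bonds along the chain from a carbonyl carbon, gives a step that stays within the scatter (a 2.0-fold lower number from compound 3 to compound 4 (0.30 log units; within the scatter)). The comparisons with the other two chains stay within it as well (a 1.6-fold lower number from compound 2 to compound 4 (0.20 log units; within the scatter); no change at the digits printed from compound 1 to compound 4 (within the scatter)), so one added chain carbon here does not set compound 4 apart, and no trend with chain length can be read across the four compounds. No measurement shown here offers an explanation for these closely spaced numbers.

The compounds shown all carry unbranched chains, so the effect of a branched chain, a much longer chain, or a chain ending in an amine or a carboxylic acid remains open. From the compounds shown here alone, whether these close numbers would hold in other cell types also remains open.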